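The compounds below may be only part of what the source reports. "The series", "measured", "known", "first", "only" and "open" are said of these compounds alone.

Of the compounds shown here, three of one series have so far been measured in a functional assay (mast cells) for inhibition, with Rattus norvegicus as the target; on this read-out higher numbers stand for an effect only at larger amounts of compound and lower numbers for an effect already at smaller amounts. Compound 1 `CC1CC/C(=N\Nc2ccc(F)cc2)c2ncc(C(=O)O)c(=O)n21` gives 1200 nM. Compound 2 `CCOc1cccc(N/N=C2\CCC(C)n3c2ncc(C(=O)O)c3=O)c1` gives 4700 nM, and compound 3 `CCOc1ccc(N/N=C2\CC[C@@H](C)n3c2ncc(C(=O)O)c3=O)cc1` gives 1000 nM. Of these three numbers compound 1 stands second highest; it and compound 3 lie within the scatter of each other, while compound 2 stands apart with a higher number beyond the scatter. Compound 4 `CC1CC/C(=N\Nc2ccc(C3CC3)cc2)c2ncc(C(=O)O)c(=O)n21` is not yet measured. It differs from compound 1 in one place: cyclopropyl in place of fluoro on an aromatic carbon. For the measured compounds named here, no measured step of this kind exists among the three, so nothing in this assay tells its size directly. Because compound 3 gives 1000 nM close to compound 1, a step beyond the scatter is not expected, and the expected step of a 1.3-fold lower number from compound 1 to compound 4 (0.12 log units; within the scatter) is small. Compound 4 is estimated at 900 nM, with a range from 300 nM to 3000 nM.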

Compound 4, half-maximal effective concentration: 1000 nM
For compound 4 the middle estimate is 1.1-fold (0.05 log units) below the measured one; the range from low to high includes it.
By their numbers in this assay, from the lowest: compounds 3, 4 and 1 (each within the scatter of the next); then compound 2.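

In this assay, for the compounds shown here, cyclopropyl in place of fluoro on an aromatic carbon, para to a large group, gives a 1.2-fold lower number from compound 1 to compound 4 (0.08 log units; within the scatter) as the first directly measured step at this position. The position therefore takes three carbons and a three-membered ring in place of a single fluorine with no step beyond the scatter. No available measurement explains why these two groups read alike. On these data alone, it remains open whether an amine or a carboxylic acid here would also stay within the scatter of compound 1, and whether a longer chain would.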